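This account rests on a few compounds, and the source may have more. Where it says the series, first, only, none or still open, it means among the compounds named here.

Values in a physicochemical assay for lipophilicity, at pH 7.4; a lower number here means a more polar compound, a higher number a more lipophilic compound:

- Compound 1 `CCc1ccc(N(Cc2ccccc2)S(=O)(=O)c2ccc3c(c2)C(=O)CC(C2CCOCC2)O3)cc1`: 4.84
- Compound 2 `CCc1ccc(N(CC(C)C)S(=O)(=O)c2ccc3c(c2)C(=O)CC(C2CCOCC2)O3)cc1`: 4.21

Of these two compounds, compound 2 stands lower, at 4.21. Compound 3 `CCc1ccc(N(C2COC2)S(=O)(=O)c2ccc3c(c2)C(=O)CC(C2CCOCC2)O3)cc1` carries oxetan-3-yl in place of isobutyl on a sulfonamide nitrogen. For the measured compounds named here, only one measured step bears on this change, a number 0.63 log units lower from compound 1 to compound 2 (beyond the scatter). That step concerned a different change, so it offers only a loose guide to size. A downward step in this assay beyond the scatter, somewhat larger than that one, is expected: a number 1.01 log units lower from compound 2 to compound 3 (beyond the scatter). The estimated value for compound 3 is 3.2, with an expected range of 2.6 to 3.8.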

Compound 3, distribution coefficient: 2.72
Compound 3: the middle estimate sits 0.48 log units above what was measured; the range from low to high includes it.
By their numbers in this assay, from the lowest: compound 3; then compound 2; then compound 1.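

In this assay the sulfonamide nitrogen proved more responsive than the earlier pair indicated: oxetan-3-yl in place of isobutyl, with the same count of heavy atoms, gives a number 1.49 log units lower from compound 2 to compound 3 (beyond the scatter) and so exceeds a number 0.63 log units lower from compound 1 to compound 2 (beyond the scatter) in size. Oxetan-3-yl in place of benzyl gives the largest step here, a number 2.12 log units lower from compound 1 to compound 3 (beyond the scatter) across the series. Nothing available accounts for the size of these steps. Still open, from the compounds shown here alone, is whether the step follows the ring oxygen or the four-membered ring itself; cyclobutyl on the same sulfonamide nitrogen would separate the two.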